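A few compounds are considered here, and "the series" means these few. Any claim that something is new, unique, unknown or untested is made for them only; others in the source may bear on it.

Measured compounds:

- Compound 1, `Cc1ccc(S(=O)(=O)N(C)c2ccc3[nH]c(-c4n[nH]c5ccccc45)cc3n2)cc1`: 16300 nM
- Compound 2, `CN(c1ccc2[nH]c(-c3n[nH]c4ccccc34)cc2n1)S(=O)(=O)c1ccc(Cl)cc1`: 12700 nM
- Compound 3, `CN(c1ccc2[nH]c(-c3n[nH]c4ccccc34)cc2n1)S(=O)(=O)c1ccc(Br)cc1`: 11500 nM

All three were tested in a functional assay on SMMC-7721 cells (Homo sapiens) for antiproliferative activity, read by MTT assay, with a stated time of 72 h; a lower number here means a stronger inhibitor, a higher number a weaker inhibitor. Compound 3 gives the lowest of the three numbers, but the steps leading to it are only a 1.1-fold lower number from compound 2 to compound 3 (0.04 log units; within the scatter) and a 1.4-fold lower number from compound 1 to compound 3 (0.15 log units; within the scatter), so the three cannot be told apart.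

Compound 4, `COc1ccc(S(=O)(=O)N(C)c2ccc3[nH]c(-c4n[nH]c5ccccc45)cc3n2)cc1OC`, has not yet been tested in this assay. It differs from compound 3 in one place: 3,4-dimethoxyphenyl in place of 4-bromophenyl on a sulfonyl sulfur.

The measured steps all concern exchanges on this same aromatic ring attached to the sulfonyl sulfur: a 1.3-fold lower number from compound 1 to compound 2 (0.11 log units; within the scatter), a 1.4-fold lower number from compound 1 to compound 3 (0.15 log units; within the scatter) and a 1.1-fold lower number from compound 2 to compound 3 (0.04 log units; within the scatter), each within the scatter. Going by the values given here, no measured step involves a methoxy group, so the new change goes beyond what the data cover. Since every exchange on this ring so far left the number where it was, compound 4 is expected to give about 12000 nM, within 5000 nM to 30000 nM. The expected step is therefore a 1.0-fold higher number from compound 3 to compound 4 (0.02 log units; within the scatter), that is, no change beyond the scatter.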

Compound 4, half-maximal inhibitory concentration: 26600 nM
Beside the measured number, compound 4's estimate is 2.2-fold (0.35 log units) below it, within the range that was stated.
By their numbers in this assay, from the lowest: compounds 3, 2, 1 and 4 (each within the scatter of the next, the first and the last beyond it).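

In this assay, going by these compounds alone, the aromatic ring on the sulfonyl sulfur is not wholly indifferent to exchange: 3,4-dimethoxyphenyl gives a 2.3-fold higher number from compound 3 to compound 4 (0.36 log units; beyond the scatter) and a 2.1-fold higher number from compound 2 to compound 4 (0.32 log units; beyond the scatter) as the first steps at this position beyond the scatter, though both are modest. Compound 1 goes against any clean split between the halogen-bearing rings and the new one: a 1.6-fold higher number from compound 1 to compound 4 (0.21 log units; within the scatter) stays within the scatter, so the 4-methylphenyl and 3,4-dimethoxyphenyl rings cannot be told apart. No measured evidence is available to explain this shift.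

The compounds shown leave open whether a ring carrying a single methoxy group would behave like the 3,4-dimethoxyphenyl ring. They also leave open how an amine or a carboxylic acid on this ring would change the number.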